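Swapping Methyl for Cyclobutyl on an Aromatic Nitrogen

This account rests on a few compounds, and the source may have more. Where it says the series, first, only, none or still open, it means among the compounds named here.

Of the compounds shown here, three with a shared core have been tested in a functional assay on RAW264.7 cells (Mus musculus) for inhibition, read by Griess assay, with stated times of 2 h and 24 h; on this read-out higher numbers stand for weaker inhibition and lower numbers for stronger inhibition. Compound 1 `COc1ccc([C@@H]2CC(=O)c3c(O)cc(OCc4cn(Cc5ccccc5)nn4)cc3O2)cc1O` gives 11000 nM, compound 2 `COc1ccc([C@@H]2CC(=O)c3c(O)cc(OCc4cn(Cc5cccc(C#N)c5)nn4)cc3O2)cc1O` gives 18000 nM, and compound 3 `COc1ccc([C@@H]2CC(=O)c3c(O)cc(OCc4cn(C)nn4)cc3O2)cc1O` gives 15200 nM. Compound 3 cannot be told apart from either of the other two, as all three numbers lie within the scatter of one another.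

Compound 4 `COc1ccc([C@@H]2CC(=O)c3c(O)cc(OCc4cn(C5CCC5)nn4)cc3O2)cc1O` has cyclobutyl in place of the methyl of compound 3 on an aromatic nitrogen: cyclobutyl in place of methyl on an aromatic nitrogen. Among the measured compounds shown here, no tested compound carries cyclobutyl, so the nearest evidence comes from changes to the group on that same nitrogen. The data show a 1.4-fold higher number from compound 1 to compound 3 (0.14 log units; within the scatter) and a 1.2-fold lower number from compound 2 to compound 3 (0.07 log units; within the scatter), and both steps lie within the scatter. Neither change moved the number measurably, so no step beyond the scatter is expected in this assay.

The expected change is a 1.1-fold lower number from compound 3 to compound 4 (0.04 log units; within the scatter). For compound 4 the estimated value is 14000 nM, with an expected range of 7500 nM to 26000 nM.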

Compound 4, half-maximal inhibitory concentration: 15300 nM
For compound 4 the middle estimate is 1.1-fold (0.04 log units) below the measured one; the range from low to high includes it.
By their numbers in this assay, from the lowest: compounds 1, 3, 4 and 2 (each within the scatter of the next).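

In this assay, a 1.0-fold higher number from compound 3 to compound 4 (0.00 log units; within the scatter) shows that a saturated ring of carbon only, with four heavy atoms, can stand on this aromatic nitrogen without a measurable change from methyl, with its single heavy atom. The comparisons with the two larger groups, a 1.2-fold lower number from compound 2 to compound 4 (0.07 log units; within the scatter) and a 1.4-fold higher number from compound 1 to compound 4 (0.14 log units; within the scatter), also stay within the scatter, so methyl, cyclobutyl, benzyl and 3-cyanobenzyl on this nitrogen cannot be told apart on this read-out. Nothing available offers an explanation for this flat result.

Going by these compounds, it remains open whether a group carrying an amine or a carboxylic acid, or a longer chain, on this nitrogen would move the number beyond the scatter. The compounds shown also leave open whether any change elsewhere on the shared core would do so.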